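This account rests on a few compounds, and the source may have more. Where it says the series, first, only, none or still open, it means among the compounds named here.

Compound 1 `O=C(O)c1cnc(-c2ccccc2O)[nH]c1=O`, compound 2 `CCOc1ccc(N(C)C)cc1-c1ncc(C(=O)O)c(=O)[nH]1`, compound 3 `CCOC(=O)c1cnc(-c2ccccc2O)[nH]c1=O`.

In a functional assay on the whole organism (strain Sprague-Dawley) for inhibition, with Rattus norvegicus as the target, with a stated time of 10 min (a higher number here means that more compound is needed for the effect, a lower number that less compound is needed), compound 1 gives only a limit, > 5 mg/kg. In this assay compound 2 gives 0.3 mg/kg. In this assay compound 3 gives 5 mg/kg, the highest of the two numbers shown, with compound 2 lower than it by a gap beyond the scatter. Within the data shown here, the single measured step, a number no higher from compound 1 to compound 3 (the limit leaves the size open), concerns the ester, and its size stays open because of the limit of > 5 mg/kg in this assay, at which 1 of the 3 values shown sits. Compound 4 `CCOC(=O)c1cnc(-c2ccccc2SCC)[nH]c1=O` differs from compound 3 by ethylsulfanyl in place of hydroxy on an aromatic carbon. Among the measured compounds shown here, no measured step touches this change; compound 2, which differs from compound 3 in two places, shows a lower number. Compound 4 is therefore expected to give 3 mg/kg, between 0.8 mg/kg and 10 mg/kg, a step of a 1.7-fold lower number from compound 3 to compound 4 (0.22 log units; within the scatter) that is estimated to stay within the scatter.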

Compound 4, dose for 50% inhibition: > 5 mg/kg
Compound 4 was reported as a limit; the forecaster's own chance of this, stated with the estimate: 25%; middle value at least 1.6-fold (0.22 log units) away from the limit.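

At this position, on an aromatic carbon ortho to a large group, ethylsulfanyl in place of hydroxy gives a number no lower from compound 3 to compound 4 (the limit leaves the size open). This is the first change shown at this place, and it brings no lower number in this assay. The size of this step and of the step at the ester cannot be read, because each involves a limit rather than a number: the limit of > 5 mg/kg in this assay, at which 2 of the 4 values shown sit.

Going by these compounds, it remains open how much higher, if at all, the number for compound 4 lies. On these data alone, it is also open whether methoxy or an amine at this place would give a lower number than hydroxy.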